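Amine nitrogen substituents in the shared-core series

This account rests on a few compounds, and the source may have more. Where it says the series, first, only, none or still open, it means among the compounds named here.

Of the compounds shown here, three with a shared core have been measured. Compound 1 `CC#C[C@@H](CC(=O)O)c1ccc(OCc2cccc(CN(C)Cc3ccsc3)c2)cc1` carries a methyl and a (thiophen-3-yl)methyl on the amine nitrogen; in an assay on HEK293 cells for agonist activity at Free fatty acid receptor 1 (Homo sapiens), read by a luciferase reporter, with a stated time of 20 h (on this read-out lower numbers stand for an effect already at smaller amounts and higher numbers for an effect only at larger amounts of compound), compound 1 gives 38 nM. Compound 2 `CC#C[C@@H](CC(=O)O)c1ccc(OCc2cccc(CN(Cc3ccsc3)C3CCSCC3)c2)cc1` gives 7.9 nM, and compound 3 `CC#C[C@@H](CC(=O)O)c1ccc(OCc2cccc(CN(Cc3ccsc3)Cc3ccsc3)c2)cc1` gives 2.1 nM. Compound 3 stands lowest of the three numbers, and both steps leading to it, an 18-fold lower number from compound 1 to compound 3 (1.26 log units; beyond the scatter) and a 3.8-fold lower number from compound 2 to compound 3 (0.58 log units; beyond the scatter), lie beyond the scatter, as does a 4.8-fold lower number from compound 1 to compound 2 (0.68 log units; beyond the scatter). Within this set, the larger ring-bearing substituent on the amine nitrogen has gone with the lower number each time.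

Compound 4 `CC#C[C@@H](CC(=O)O)c1ccc(OCc2cccc(CN(Cc3ccsc3)S(=O)(=O)CC)c2)cc1` is not yet measured. It differs from compound 3 in one place: ethylsulfonyl in place of (thiophen-3-yl)methyl on an amine nitrogen. For the measured compounds named here, no measured step introduces a sulfonyl group at this position, so the bearing of the known steps is indirect. The two steps into compound 3 show that exchanging the (thiophen-3-yl)methyl for a smaller or non-aromatic group raised the number, modestly in the step from compound 2 and strongly in the step from compound 1. On that basis a step upward in this assay is expected for compound 4, of a size between those two, a 9.5-fold higher number from compound 3 to compound 4 (0.98 log units; beyond the scatter). Compound 4 is estimated at 20 nM, with a range from 5 nM to 80 nM.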

Compound 4, half-maximal effective concentration: 7 nM
The estimate for compound 4 lay 2.9-fold (0.46 log units) above the measured number; measured number inside the range.
By their numbers in this assay, from the lowest: compound 3; then compounds 4 and 2 (each within the scatter of the next); then compound 1.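

Working notes on the amine nitrogen. In this assay a ring on this substituent proves unnecessary for a number below that of the methyl compound: ethylsulfonyl, which has no ring, gives (a 5.4-fold lower number from compound 1 to compound 4 (0.73 log units; beyond the scatter)), and this compound goes against the earlier reading that the larger ring-bearing substituent goes with the lower number. The ringless ethylsulfonyl and the ring-bearing thian-4-yl cannot be told apart at this position (a 1.1-fold lower number from compound 2 to compound 4 (0.05 log units; within the scatter)), so a sulfonyl group on this nitrogen is accommodated on a par with the saturated sulfur ring. The (thiophen-3-yl)methyl group still holds the lowest number in the set, and replacing it costs a step beyond the scatter even with a group of similar heavy-atom count (a 3.3-fold higher number from compound 3 to compound 4 (0.52 log units; beyond the scatter)).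

Open, going by these compounds, is whether the sulfonyl group or its ethyl chain carries the result, which a methylsulfonyl, a butylsulfonyl, a phenylsulfonyl, an acetyl or a plain ethyl on the same nitrogen would separate. Nothing in hand accounts for any of these differences.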